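The source may hold more compounds than are shown below. What is called first, only, known or untested is meant among the compounds shown, and "the series" means these compounds.

Measured so far in a functional assay on HT-29 cells (Homo sapiens) for antiproliferative activity, read by MTT assay, with a stated time of 72 h; on this read-out lower numbers stand for stronger inhibition and higher numbers for weaker inhibition:
compound 1 `C=C(Br)C(=O)Nc1ccc2c(c1)/C(=C/c1cccs1)C(=O)N2`: compound 1 gives 240 nM
compound 2 `C=C(Br)C(=O)Nc1ccc2c(c1)/C(=C\c1cccs1)C(=O)N2`: compound 2 gives 5500 nM
compound 3 `C#CC(=O)Nc1ccc2c(c1)/C(=C/c1ccc[nH]1)C(=O)N2`: compound 3 gives 2300 nM

Compound 2 stands at the highest of the three numbers in this assay; compound 3 is nearest to it and compound 1 furthest from it. Going by the values given here, the one measured step, a 23-fold higher number from compound 1 to compound 2 (1.36 log units; beyond the scatter), is large, and it rests on (the fact that compounds 1 and 2 differ only in the configuration as drawn); it says nothing about a change of the aromatic ring itself.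

Compound 4 `C=C(Br)C(=O)Nc1ccc2c(c1)/C(=C\c1ccsc1)C(=O)N2` differs from compound 2 in one place: thiophen-3-yl in place of thiophen-2-yl on a double-bonded chain carbon bound to a double-bonded ring carbon. Among the compounds with values here, no measured pair swaps thiophen-2-yl for thiophen-3-yl, so none of the measured steps bears on this change, and the drawn configuration of compound 4 matches that of compound 2. With nothing in the data to push the number either way, no step beyond the scatter is expected in this assay.

The expected step from compound 2 to compound 4 is therefore no change at the digits printed from compound 2 to compound 4 (within the scatter). Compound 4 is estimated at 5500 nM in this assay, within a range from 2000 nM to 15000 nM.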

Compound 4, half-maximal inhibitory concentration: 310 nM
Estimate against measurement, compound 4: 18-fold (1.25 log units) above; the whole stated range lies above it.
By their numbers in this assay, from the lowest: compounds 1 and 4 (each within the scatter of the next); then compound 3; then compound 2.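

In this assay, putting thiophen-3-yl in place of thiophen-2-yl on a double-bonded chain carbon bound to a double-bonded ring carbon gives an 18-fold lower number from compound 2 to compound 4 (1.25 log units; beyond the scatter). The earlier compounds shown here showed only that this part of the series responds to the drawn configuration of the double bond; this pair shows that it also responds to the point of attachment of the thiophene, although the two groups have identical heavy-atom, donor and acceptor counts. Nothing at hand accounts for the size of this step.

On these data alone, it remains open whether a step of this kind also holds with the double bond drawn as in compound 1. Also open, as far as these compounds go, is how a phenyl or a furan-3-yl group would read at this place.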